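Aryl-to-pyrazolyl swap on the sulfonamide series

This account rests on a few compounds, and the source may have more. Where it says the series, first, only, none or still open, it means among the compounds named here.

Measured so far:
- compound 1, `COc1ccc(NS(=O)(=O)c2ccc(-c3ccccn3)s2)cc1N1C[C@@H](C)N[C@@H](C)C1`, in a functional assay for agonist activity at growth hormone secretagogue receptor type 1 (Homo sapiens), read by FLIPR (a lower number here means a smaller maximal response, a higher number a larger maximal response), gives 0.9
- compound 2, `COc1ccc(N2C[C@@H](C)N[C@@H](C)C2)cc1NS(=O)(=O)c1ccc(-c2cc(Cl)ccc2F)cc1`, in this assay gives 1

Compound 2 holds the higher of the two numbers, but the gap to compound 1 is within the usual scatter, so the two compounds read as essentially alike in maximal response; both reach close to the full reference response. Among the measured compounds shown here, no step between two measured compounds differing in one place is available, so nothing yet ties a single structural change to a shift in intrinsic activity.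

Compound 3, `COc1ccc(N2C[C@@H](C)N[C@@H](C)C2)cc1NS(=O)(=O)c1ccc(-n2cccn2)cc1`, is the next member to be measured. Compared with compound 2 it carries 1H-pyrazol-1-yl in place of 5-chloro-2-fluorophenyl on an aromatic carbon. Compound 1 shows that a nitrogen-containing heteroaryl at the distal position is compatible with a near-full response, which supports expecting the change in compound 3 to leave the read-out largely unchanged. The step is therefore expected to be small, estimated at a number 0.10 lower from compound 2 to compound 3 (within the scatter), lying within the scatter, with any drift more likely downward than upward. For compound 3 the intrinsic activity in this assay is estimated at 0.9, with a likely range from 0.6 to 1.05.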

Compound 3, intrinsic activity: the largest response reached, as a fraction of the reference agonist's: 0.8
For compound 3 the middle estimate is 0.10 above the measured one, within the range that was stated.
By their numbers in this assay, from the lowest: compounds 3, 1 and 2 (each within the scatter of the next, the first and the last beyond it).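

In this assay the step shows that the group on this aromatic carbon, para to a large group, does affect maximal response: 1H-pyrazol-1-yl in place of 5-chloro-2-fluorophenyl gives a number 0.20 lower from compound 2 to compound 3 (beyond the scatter) and so ties a single change to a shift beyond the usual scatter. The shift is modest, and compound 3 at 0.8 still reaches most of the reference agonist's response, so this change lowers the maximal response without abolishing agonism. Nothing available bears on why the response falls.

This single pair cannot separate the change from a six-membered to a five-membered ring from the loss of the chlorine and fluorine or the entry of the two ring nitrogens, and an unsubstituted phenyl at this place would help to divide those contributions. It also leaves open how the response would run with a primary amine or a carboxylic acid on this carbon, and whether the same change would give a step of similar size on another core.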